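Stereochemistry of the methylcyclopropyl amide: one centre flipped

This account rests on a few compounds, and the source may have more. Where it says the series, first, only, none or still open, it means among the compounds named here.

Measured compounds:
Compound 1 `CC(C)C(=O)N1CC2CC(C1)N2`: 130 nM
Compound 2 `C[C@H]1C[C@H]1C(=O)N1CC2CC(C1)N2`: 7 nM

Compound 1 is the isopropyl amide of the shared core, and in an assay on SH-EP1 cells for displacement of a labelled ligand from Neuronal acetylcholine receptor; alpha4/beta2 (Homo sapiens), read by scintillation counting (on this read-out lower numbers stand for stronger inhibition and higher numbers for weaker inhibition), compound 1 gives 130 nM. Compound 2 carries a 2-methylcyclopropyl group on the carbonyl carbon instead, and in this assay compound 2 gives 7 nM. Among the compounds with values here, the single measured step, a 19-fold lower number from compound 1 to compound 2 (1.27 log units; beyond the scatter), is the only comparison available, and compound 2 stands at the lower of the two numbers.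

Compound 3 `C[C@H]1C[C@@H]1C(=O)N1CC2CC(C1)N2` is the unmeasured partner of compound 2: the two compounds have the same atoms and bonds; at least one stereo element is drawn with a configuration in one of them and without one in the other: 1 of 4 stereo elements differ; a stereocentre at a saturated ring carbon is drawn R in compound 2 and S in compound 3. No measured step concerns a change of configuration, so nothing shown says how large or in which direction such a step runs. The step of a 19-fold lower number from compound 1 to compound 2 (1.27 log units; beyond the scatter) shows only that this region of the molecule responds strongly to change. On that basis compound 3 is expected to give a somewhat higher number than compound 2, an estimated step of a 2.9-fold higher number from compound 2 to compound 3 (0.46 log units; beyond the scatter). The estimate for compound 3 in this assay is 20 nM, within a range of 5 nM to 80 nM.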

Compound 3, inhibition constant: 17 nM
Compound 3: the middle estimate sits 1.2-fold (0.07 log units) above what was measured, and the stated range covers the measured number.
By their numbers in this assay, from the lowest: compound 2; then compound 3; then compound 1.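

In this assay the configuration at a saturated ring carbon matters, but only modestly: changing it from R to S gives a 2.4-fold higher number from compound 2 to compound 3 (0.39 log units; beyond the scatter). The gain over the isopropyl amide survives this change, with a 7.6-fold lower number from compound 1 to compound 3 (0.88 log units; beyond the scatter), so 2-methylcyclopropyl gives a lower number than isopropyl in both drawn forms, and the change of configuration is a smaller step than the change of group. How firmly this step can be tied to a single configuration depends on a feature of the drawings: the fact that one of compounds 2 and 3 is drawn with a defined configuration and the other without, at the place where they differ

The compounds shown leave open how the remaining stereocentre of the cyclopropyl ring affects the number. As far as these compounds go, what a plain cyclopropyl group without the methyl, or a butyl chain on the carbonyl carbon, would give also stays open.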